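Cinnamoyl in place of benzoyl on a selenoether amide

This account rests on a few compounds, and the source may have more. Where it says the series, first, only, none or still open, it means among the compounds named here.

Measured so far:
Compound 1, `COc1ccc(N(CC(=O)NCCCSc2ccccc2)C(=O)CCSC2=C(C)C(=O)c3ccccc3C2=O)cc1`, gives 26000 nM in an ADME assay on cells (Fibroblast, Homo sapiens) for cytotoxicity, read by MTT assay, with a stated time of 24 h; a lower number here means a stronger inhibitor, a higher number a weaker inhibitor.
Compound 2, `COc1ccc(N(CC(=O)NCCC[Se]c2ccccc2)C(=O)c2ccccc2)cc1`, gives only a limit in this assay, namely >= 100000 nM.
Compound 3, `COc1ccc(N(CC(=O)NCCC[Se]c2ccccc2)C(=O)CCSC2=C(C)C(=O)c3ccccc3C2=O)cc1`, gives 24000 nM in this assay.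

Compound 2 therefore stands at a limit rather than at a number, (the limit of >= 100000 nM in this assay, at which 1 of the 3 values shown sits). For the measured compounds named here, the only step measured between two compounds is a 1.1-fold lower number from compound 1 to compound 3 (0.03 log units; within the scatter), and it concerns the chain end that compounds 2 and 4 share unchanged, not the carbonyl side where compound 4 differs. Compounds 1 and 3 carry a larger group on that carbonyl carbon than compound 2 and both sit well inside the measured range, whereas compound 2 with its benzoyl reaches only the limit.

The untested compound 4, `COc1ccc(N(CC(=O)NCCC[Se]c2ccccc2)C(=O)/C=C/c2ccccc2)cc1`, differs from compound 2 by 2-phenylethenyl in place of phenyl on a carbonyl carbon. No measured step bears directly on this change, so nothing shown gives it a direction or size. The step of an at least 1.2-fold lower number from compound 2 to compound 4 (0.09 log units; that floor lies within the scatter) is therefore expected to be small against the scatter, with a fair chance that compound 4 again gives only a limit. Compound 4 is estimated at 80000 nM, within a range from 30000 nM to 100000 nM.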

Compound 4, half-maximal inhibitory concentration: >= 100000 nM
Compound 4 ended at the assay's limit; the forecaster's own chance of this, stated with the estimate: 55%; middle value at least 1.2-fold (0.09 log units) from the limit.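

Compound 4, like compound 2, gives only a limit in this assay, so no step can be read between compound 2 and compound 4: the limit of >= 100000 nM in this assay, at which 2 of the 4 values shown sit.

The compounds shown leave open whether 2-phenylethenyl in place of phenyl on a carbonyl carbon changes the number in this assay at all, and in which direction.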